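Thiosemicarbazone series: para-substituent swap on the acetophenone arm

This account rests on a few compounds, and the source may have more. Where it says the series, first, only, none or still open, it means among the compounds named here.

Compound 3 `COc1ccc(/C(C)=N/NC(=S)NC(C)(C)[C@H]2CC=C(C)CC2)cc1` carries a methoxy on the aromatic ring; in a functional assay on OVCAR-3 cells (Homo sapiens) for inhibition, read by sulforhodamine B assay, with a stated time of 48 h (on this read-out higher numbers stand for weaker inhibition of growth and lower numbers for stronger inhibition of growth), compound 3 gives 74900 nM. Compound 1 `CC1=CC[C@H](C(C)(C)NC(=S)N/N=C/c2cccs2)CC1` gives 13100 nM in this assay, so compound 3 holds the higher of the two numbers reported. Compound 2 `CC1=CC[C@H](C(C)(C)NC(=S)N/N=C(\C)c2ccccc2)CC1` reaches only the assay limit of > 100000 nM in this assay, and that limit is the one noted as the limit of > 100000 nM in this assay, at which 1 of the 3 values shown sits. Along the measured step, an at least 1.3-fold lower number from compound 2 to compound 3 (0.12 log units; that floor lies within the scatter), the change is methoxy in place of hydrogen on an aromatic carbon, and its size does not clear the usual scatter.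

Compound 4 `CC1=CC[C@H](C(C)(C)NC(=S)N/N=C(\C)c2ccc([N+](=O)[O-])cc2)CC1` differs from compound 3 by nitro in place of methoxy on an aromatic carbon. Going by the values given here, the only measured step that touches the same aromatic carbon, an at least 1.3-fold lower number from compound 2 to compound 3 (0.12 log units; that floor lies within the scatter), stayed within the scatter, so no shift beyond the scatter is expected from compound 3 to compound 4 in this assay; the expected step is a 1.2-fold lower number from compound 3 to compound 4 (0.10 log units; within the scatter). Compound 4 is therefore estimated at 60000 nM in this assay, within a range from 20000 nM to 180000 nM, with a real chance that only a limit is returned.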

Compound 4, concentration for 50% growth inhibition: 7700 nM
Beside the measured number, compound 4's estimate is 7.8-fold (0.89 log units) above it; the whole stated range lies above it.
By their numbers in this assay, from the lowest: compounds 4 and 1 (each within the scatter of the next); then compound 3. At a limit, above all of these: compound 2.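

The aromatic carbon para to a large group responds strongly to the choice of substituent in this assay: nitro in place of methoxy gives a 9.7-fold lower number from compound 3 to compound 4 (0.99 log units; beyond the scatter), whereas methoxy in place of hydrogen showed only an at least 1.3-fold lower number from compound 2 to compound 3 (0.12 log units; that floor lies within the scatter). Nitro in place of hydrogen gives an at least 12-fold lower number from compound 2 to compound 4 (1.11 log units; beyond the scatter), so on this series nitro, and not methoxy, moves the number beyond the scatter from the unsubstituted ring. The size of that step is only a floor, since compound 2 stands at a limit of the assay and not at a number: the limit of > 100000 nM in this assay, at which 1 of the 4 values shown sits.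

Going by these compounds, with only hydrogen, methoxy and nitro at this carbon, it stays open whether the shift belongs to nitro alone or also appears with a nitrile, a trifluoromethyl or an amine. On these data alone, it also stays open whether nitro at this carbon gives a similar step on other cell lines.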